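Cytotoxicity notes on two thienopyrimidine-type analogues and one gap

The source may report more compounds than this note shows. Statements on the series, on what has been measured and on what is new or still open speak of the compounds shown alone.

Measured so far:
- compound 1, `Cc1cc(-c2ccc(C#N)cc2)cc(C)c1Oc1nc(Nc2ccc(C#N)nc2)nc2sccc12`: 181000 nM
- compound 2, `Cc1cc(-c2ccc(F)cc2)cc(C)c1Oc1nc(Nc2ccc(C#N)c(F)c2)nc2sccc12`: 28900 nM

In a toxicity assay on MT4 cells (Homo sapiens) for cytotoxicity, read by MTT assay, with a stated time of 5 days (on this read-out lower numbers stand for higher toxicity in this test and higher numbers for lower toxicity in this test), compound 1 gives 181000 nM. In this assay compound 2 gives 28900 nM, the lowest of the two numbers shown; compound 1 stands a good deal higher, beyond the scatter. Compound 1 and compound 2 differ in two places at once, so the two values alone do not say which change carries the gap.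

Compound 3, `Cc1cc(-c2ccc(F)cc2)cc(C)c1Oc1nc(Nc2ccc(C#N)nc2)nc2sccc12`, has not been measured. Relative to compound 2 it carries 6-cyanopyridin-3-yl in place of 4-cyano-3-fluorophenyl on a nitrogen on an aromatic ring, which brings its amine-side ring to that of compound 1 while keeping the 4-fluorophenyl of compound 2. A step upward in this assay is expected, of moderate size, toward but not necessarily reaching compound 1, which gives 181000 nM with a second difference still in place. For compound 3 the expected step is a 2.2-fold higher number from compound 2 to compound 3 (0.35 log units; beyond the scatter). Compound 3 is estimated at 65000 nM, within 22000 nM to 190000 nM.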

Compound 3, half-maximal cytotoxic concentration: 2230 nM
Compound 3: the middle estimate sits 29-fold (1.46 log units) above what was measured, and the stated range ends above it.
By their numbers in this assay, from the lowest: compound 3; then compound 2; then compound 1.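

In this assay, 6-cyanopyridin-3-yl in place of 4-cyano-3-fluorophenyl on a nitrogen on an aromatic ring gives a 13-fold lower number from compound 2 to compound 3 (1.11 log units; beyond the scatter), so this single change moves the read-out towards higher toxicity in this test. With 6-cyanopyridin-3-yl held constant, fluoro in place of cyano on an aromatic carbon gives an 81-fold lower number from compound 1 to compound 3 (1.91 log units; beyond the scatter), so this change also lowers the number by a large step, and the two compounds that differ from compound 3 in one place each stand well above it. No measurement shown gives a reason for either step.

From the compounds shown here alone, it remains open whether the change on the nitrogen keeps its direction and size when cyano rather than fluoro sits on the aromatic carbon. Going by these compounds, it also remains open how a chloro, methoxy or amino group on that carbon would compare with fluoro and cyano.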